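The source may hold more compounds than are shown below. What is called first, only, known or untested is meant among the compounds shown, and "the series" means these compounds.

Of the compounds shown here, two have been measured in a functional assay on K562 cells (Homo sapiens) for cytotoxicity, read by trypan blue exclusion, with a stated time of 96 h; a lower number here means a stronger inhibitor, a higher number a weaker inhibitor. Compound 1 `COc1ccc(NS(=O)(=O)/C=C/c2c(F)cc(F)cc2F)cc1` gives 15000 nM in this assay, while compound 2 `COC(=O)C(C)Nc1cc(NS(=O)(=O)/C=C/c2c(OC)cc(OC)cc2OC)ccc1OC` gives 300 nM, the lower of the two numbers; its gap to compound 1 lies well beyond the usual scatter. Compound 3 `COc1cc(OC)c(/C=C/S(=O)(=O)Nc2ccc(OC)c(NC(C(=O)O)c3ccccc3)c2)c(OC)c1` has not been measured. Within the data shown here, it differs from compound 2 in one place: carboxy(phenyl)methyl in place of 1-(methoxycarbonyl)ethyl on a nitrogen on an aromatic ring No measured pair shows this change, so only a modest shift toward a higher number is expected, a 2.0-fold higher number from compound 2 to compound 3 (0.30 log units; within the scatter). Compound 3 is therefore estimated at 600 nM in this assay, within a range from 150 nM to 2500 nM.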

Compound 3, half-maximal inhibitory concentration: 300 nM
Compound 3: the middle estimate sits 2.0-fold (0.30 log units) above what was measured; the range from low to high includes it.
By their numbers in this assay, from the lowest: compounds 2 and 3 (each within the scatter of the next); then compound 1.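

In this assay there is no change at the digits printed from compound 2 to compound 3 (within the scatter) even though 1-(methoxycarbonyl)ethyl gives way to the larger carboxy(phenyl)methyl on the nitrogen. This position therefore accepts a six-membered aromatic ring and a free carboxy group in place of the methyl ester without a readable shift in the number. Nothing on hand explains why the number holds steady. Going by these compounds, the ring and the carboxy group enter in a single change, so what each does alone stays open. Also open, on these data alone, is how a plain benzyl group or an aminoethyl chain on this nitrogen would read.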